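Notes on a ring-nitrogen aryl swap in the series

The compounds below may be only part of what the source reports. "The series", "measured", "known", "first", "only" and "open" are said of these compounds alone.

Compound 2 `COc1ccc(N2CCN(C(=S)N/N=C3\C(=O)Nc4ccc(Cl)cc43)CC2)cc1` gives 7740 nM in a functional assay on HCT-116 cells (Homo sapiens) for inhibition, read by MTT assay, with a stated time of 72 h; a lower number here means a stronger inhibitor, a higher number a weaker inhibitor. Compound 1 `O=C1Nc2cc(Br)ccc2/C1=N/NC(=S)N1CCN(c2ccccc2)CC1` gives 14500 nM in this assay; the number for compound 2 is the lower of the two, but the gap lies within the scatter, so no order between them is claimed. Compound 3 `O=C1Nc2ccc(Cl)cc2/C1=N/NC(=S)N1CCN(c2ccccc2F)CC1`, not yet measured, differs from compound 2 by 2-fluorophenyl in place of 4-methoxyphenyl on an amine nitrogen in a ring. Within the data shown here, no measured step of this kind exists in the set, and a step beyond the scatter is not expected in either direction. Compound 3 is therefore expected to give 10000 nM (range 4000 nM to 25000 nM) in this assay. The expected step is a 1.3-fold higher number from compound 2 to compound 3 (0.11 log units; within the scatter).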

Compound 3, half-maximal inhibitory concentration: 8290 nM
Beside the measured number, compound 3's estimate is 1.2-fold (0.08 log units) above it, and the stated range covers the measured number.
By their numbers in this assay, from the lowest: compounds 2, 3 and 1 (each within the scatter of the next).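

In this assay, among these compounds, the change to 2-fluorophenyl in place of 4-methoxyphenyl on the amine nitrogen in the ring gives a 1.1-fold higher number from compound 2 to compound 3 (0.03 log units; within the scatter) and is the first single-place step that can be read. At this position, the hydrogen-bond acceptor counted for 4-methoxyphenyl can be absent from the entering 2-fluorophenyl without a step beyond the scatter. No measurement bears on the reason for this result. Still open, going by these compounds, is whether a phenyl ring is needed at this nitrogen at all, and whether a pyridine ring, a carboxylic acid or a plain methyl group there would give a step beyond the scatter.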